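The source may report more compounds than this note shows. Statements on the series, on what has been measured and on what is new or still open speak of the compounds shown alone.

Three compounds have so far been measured in an assay on isolated protein for inhibition of aldehyde dehydrogenase 1A1 (Homo sapiens), read by spectrophotometry, tested at 10 uM; on this read-out lower numbers stand for less inhibition and higher numbers for more inhibition at the one concentration tested (going by the name of the read-out):

compound 1 `O=C(C1CC1)N1CCN(Cc2nc3ccccc3n2Cc2ccccc2C(F)(F)F)CC1`, which gives 56.3%
compound 2 `O=C(C1CC1)N1CCN(Cc2nc3ccccc3n2Cc2cccc(F)c2)CC1`, which gives 27.2%
compound 3 `CC(C)CCn1c(CN2CCN(C(=O)C3CC3)CC2)nc2ccccc21`, which gives 70%

Compound 3 stands highest of the three, and both steps leading to it lie beyond the scatter: a number 13.7 percentage points higher from compound 1 to compound 3 (beyond the scatter) and a number 42.8 percentage points higher from compound 2 to compound 3 (beyond the scatter). The two aryl-bearing compounds also differ from each other, as a number 29.1 percentage points lower from compound 1 to compound 2 (beyond the scatter) shows.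

Compound 4 `Cc1ccc(Cn2c(CN3CCN(C(=O)C4CC4)CC3)nc3ccccc32)cc1` has not yet been measured. It differs from compound 3 in one place: 4-methylphenyl in place of isobutyl on a saturated chain carbon bound to an aromatic nitrogen. This change runs in the opposite direction to the two steps that bear on it, since in each of a number 13.7 percentage points higher from compound 1 to compound 3 (beyond the scatter) and a number 42.8 percentage points higher from compound 2 to compound 3 (beyond the scatter) an aryl group was exchanged for isobutyl and the read-out rose. Compound 4 restores an aryl group, so a drop is expected, and its size is estimated to fall between the two measured aryl-to-isobutyl steps, giving a number 28 percentage points lower from compound 3 to compound 4 (beyond the scatter). Compound 4 is therefore expected to give about 42%, with a range from 20% to 62%.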

Compound 4, a percentage reported as inhibition, at one concentration (the size of the read-out at that concentration, not a potency): 51.5%
Compound 4: middle estimate off by 9.5 percentage points, on the low side; the measured number falls inside the stated range.
By their numbers in this assay, from the lowest: compound 2; then compounds 4 and 1 (each within the scatter of the next); then compound 3.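

In this assay, the 4-methylphenyl group shows that a third aryl group on a saturated chain carbon bound to an aromatic nitrogen also falls short of isobutyl, with a number 18.5 percentage points lower from compound 3 to compound 4 (beyond the scatter). The choice of aryl group matters as well, but not in every pair: there is a number 24.3 percentage points higher from compound 2 to compound 4 (beyond the scatter), while there is only a number 4.8 percentage points lower from compound 1 to compound 4 (within the scatter). Thus 4-methylphenyl and 2-(trifluoromethyl)phenyl cannot be told apart here, and 3-fluorophenyl stands clearly lowest of the three aryl groups.

No evidence is at hand to account for these differences. The compounds shown also leave open whether a longer chain, or a chain ending in an amine or a carboxylic acid, would match or pass isobutyl at this position.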